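This account rests on a few compounds, and the source may have more. Where it says the series, first, only, none or still open, it means among the compounds named here.

Working notes on the series

The shared core carries a sulfonamide, a chlorine and a benzylthio group, with a five-membered ring bearing a variable substituent. Compound 1 `NS(=O)(=O)c1cc(-c2nnc(Cn3cc(-c4ccccc4)nn3)o2)c(Cl)cc1SCc1ccccc1` gives 0.21 h in an ADME assay on microsomes from liver (Homo sapiens) for metabolic stability, read by LC-MS, using NADPH, tested at 5 uM; on this read-out higher numbers stand for a longer-lived compound and lower numbers for a shorter-lived compound. Compound 2 `NCc1nnc(-c2cc(S(N)(=O)=O)c(SCc3ccccc3)cc2Cl)o1` gives 0.263 h, and compound 3 `NS(=O)(=O)c1cc(-c2nnc(CNC(=O)c3ccccc3)o2)c(Cl)cc1SCc1ccccc1` gives 0.187 h. All three numbers lie within the scatter of one another: the step of a 1.3-fold higher number from compound 1 to compound 2 (0.10 log units; within the scatter), the step of a 1.1-fold lower number from compound 1 to compound 3 (0.05 log units; within the scatter) and the step of a 1.4-fold lower number from compound 2 to compound 3 (0.15 log units; within the scatter) are each too small to count as a change. Within the data shown here, compound 3 stands at the lower edge of this narrow band, but no measured step separates it from the others beyond the scatter.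

Compound 4 `NS(=O)(=O)c1cc(-c2nnc(/C=C/c3ccc(Br)cc3)o2)c(Cl)cc1SCc1ccccc1` is not yet measured. It differs from compound 3 by 2-(4-bromophenyl)ethenyl in place of benzamidomethyl on an aromatic carbon. Every measured step in this set concerns the same position and none went beyond the scatter, so for the change to compound 4 no step beyond the scatter is expected in this assay; the expected step is a 1.1-fold higher number from compound 3 to compound 4 (0.03 log units; within the scatter). Compound 4 is therefore estimated at 0.2 h, with a range from 0.1 h to 0.4 h.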

Compound 4, half-life: 0.6 h
Compound 4: the middle estimate sits 3.0-fold (0.48 log units) below what was measured, outside the stated range (above it).
By their numbers in this assay, from the lowest: compounds 3, 1 and 2 (each within the scatter of the next); then compound 4.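

In this assay this position on the five-membered aromatic ring can move the half-life beyond the scatter, and compound 4 stands apart from all three earlier compounds in modest steps (a 3.2-fold higher number from compound 3 to compound 4 (0.51 log units; beyond the scatter)) (a 2.3-fold higher number from compound 2 to compound 4 (0.36 log units; beyond the scatter)) (a 2.9-fold higher number from compound 1 to compound 4 (0.46 log units; beyond the scatter)). The earlier groups, benzamidomethyl, aminomethyl and (4-phenyl-1H-1,2,3-triazol-1-yl)methyl, all place a saturated chain carbon on this ring atom and stay within the scatter of one another, so only 2-(4-bromophenyl)ethenyl, with its ethenyl link and bromine, separates from that set. Nothing measured here gives a reason for the higher number.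

The ethenyl link and the bromine enter together, so their shares in the step remain unresolved. A 2-phenylethenyl group without the bromine and a saturated 2-(4-bromophenyl)ethyl chain would separate the two.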